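This account rests on a few compounds, and the source may have more. Where it says the series, first, only, none or still open, it means among the compounds named here.

Working notes on the series. The shared core appears in compound 1 `Cc1ccc(-n2nc(C(=O)Nc3ccc(Oc4ncnc5[nH]ccc45)c(F)c3)c(C)cc2=O)cc1`, compound 2 `Cc1cc(=O)n(-c2ccc(Br)cc2F)nc1C(=O)Nc1ccc(Oc2ncnc3[nH]ccc23)c(F)c1` and compound 3 `Cc1cc(=O)n(-c2ccc(Br)cc2F)nc1C(=O)Nc1ccc(Oc2ncnc3c2ccn3C)c(F)c1`. In a functional assay on HepG2 cells (Homo sapiens) for cytotoxicity, read by MTT assay, with a stated time of 72 h (on this read-out higher numbers stand for weaker inhibition and lower numbers for stronger inhibition), compound 1 gives 18800 nM, and compound 2 gives 32000 nM. For compound 3 this assay reports only a limit, > 60000 nM. For the measured compounds named here, both steps so far, a 1.7-fold higher number from compound 1 to compound 2 (0.23 log units; within the scatter) and an at least 1.8-fold higher number from compound 2 to compound 3 (0.27 log units; that floor lies within the scatter), stay within the scatter, and the floor of the second rests on (the limit of > 60000 nM in this assay, at which 1 of the 3 values shown sits). Compound 3 therefore stands at the edge of the numbers shown, without a number of its own.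

Compound 4 `Cc1ccc(-n2nc(C(=O)Nc3ccc(Oc4ncnc5c4ccn5C)c(F)c3)c(C)cc2=O)cc1` is the next step: 4-methylphenyl in place of 4-bromo-2-fluorophenyl on an aromatic nitrogen. Going by the values given here, one measured step bears on this change, running the other way with the same two groups on the same aromatic nitrogen: a 1.7-fold higher number from compound 1 to compound 2 (0.23 log units; within the scatter). No step beyond the scatter is therefore expected in this assay, in either direction. The expected step is an at least 1.2-fold lower number from compound 3 to compound 4 (0.07 log units; that floor lies within the scatter). Compound 4 is estimated at 50000 nM in this assay, within 20000 nM to 150000 nM, with a fair chance that again only a limit is reported.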

Compound 4, half-maximal inhibitory concentration: > 60000 nM
Compound 4: a limit, no number (the forecaster's own chance of this, stated with the estimate: 55%); middle value at least 1.2-fold (0.07 log units) from the limit.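

Methyl in place of hydrogen on an aromatic nitrogen now gives a step beyond the scatter in this assay, an at least 3.1-fold higher number from compound 1 to compound 4 (0.50 log units; beyond the scatter), which the floor from compound 2 to compound 3 could not show. With that methyl in place, the size of the step between 4-bromo-2-fluorophenyl and 4-methylphenyl cannot be read: the limit of > 60000 nM in this assay, at which 2 of the 4 values shown sit. Whether the methyl change has the same size with either group on the other aromatic nitrogen also stays unsettled: the same change on two cores in this assay, an at least 1.8-fold higher number (0.27 log units; that floor lies within the scatter) from compound 2 to compound 3 and an at least 3.1-fold higher number (0.50 log units; beyond the scatter) from compound 1 to compound 4; the limit leaves it open whether they differ.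

The compounds shown leave open how weak compound 3 and compound 4 really are, and so whether the two groups differ at all once the methyl is present. Also open, going by these compounds, is whether an ethyl group, or a chain ending in an amine, on that same aromatic nitrogen would give a number in this assay.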